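Shared Core, New Arm: An Estimate for Compound 4

A few compounds are considered here, and "the series" means these few. Any claim that something is new, unique, unknown or untested is made for them only; others in the source may bear on it.

compound 1, `CN1CCN(Cc2nnc(-c3cc(S(N)(=O)=O)c(SCc4ccccc4)cc3Cl)o2)CC1`, 75000 nM
compound 2, `NS(=O)(=O)c1cc(-c2nnc(Cn3cc(-c4ccccc4)nn3)o2)c(Cl)cc1SCc1ccccc1`, 75000 nM
compound 3, `NS(=O)(=O)c1cc(-c2nnc(CNS(=O)(=O)c3ccc(Cl)cc3)o2)c(Cl)cc1SCc1ccccc1`, 32000 nM

Three compounds share one core and differ only in the arm carried on the five-membered aromatic ring with 2 nitrogen and 1 oxygen. In a functional assay on HCT-116 cells (Homo sapiens) for cytotoxicity, read by MTT assay, with a stated time of 72 h (on this read-out lower numbers stand for stronger inhibition and higher numbers for weaker inhibition), compound 3 gives the lowest of the three numbers: the steps of a 2.3-fold lower number from compound 1 to compound 3 (0.37 log units; beyond the scatter) and a 2.3-fold lower number from compound 2 to compound 3 (0.37 log units; beyond the scatter) are both modest, while no change at the digits printed from compound 1 to compound 2 (within the scatter).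

Compound 4, `NS(=O)(=O)c1cc(-c2nnc(/C=C/c3c(Cl)cccc3Cl)o2)c(Cl)cc1SCc1ccccc1`, differs from compound 3 in that (2-(2,6-dichlorophenyl)ethenyl in place of (((4-chlorophenyl)sulfonyl)amino)methyl on an aromatic carbon). Within the data shown here, no measured step makes this exact change; the two that bear on it, a 2.3-fold lower number from compound 1 to compound 3 (0.37 log units; beyond the scatter) and a 2.3-fold lower number from compound 2 to compound 3 (0.37 log units; beyond the scatter), show that swapping this arm moved the number only modestly. Compound 4 is therefore expected to give about 30000 nM in this assay, between 10000 nM and 90000 nM. The step this expectation implies is a 1.1-fold lower number from compound 3 to compound 4 (0.03 log units; within the scatter).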

Compound 4, half-maximal inhibitory concentration: 32000 nM
For compound 4 the middle estimate is 1.1-fold (0.03 log units) below the measured one; the measured number falls inside the stated range.
By their numbers in this assay, from the lowest: compounds 3 and 4 (each within the scatter of the next); then compounds 1 and 2 (each within the scatter of the next).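

In this assay the arm can lose its sulfonyl amino link and all its hydrogen-bond donors and acceptors, as 2-(2,6-dichlorophenyl)ethenyl enters with no change at the digits printed from compound 3 to compound 4 (within the scatter) in the number. Compound 4 also keeps the modest gains of compound 3, with a 2.3-fold lower number from compound 2 to compound 4 (0.37 log units; beyond the scatter) and a 2.3-fold lower number from compound 1 to compound 4 (0.37 log units; beyond the scatter) alongside. Nothing given here accounts for this result. Still open, as far as these compounds go, is whether a carboxylic acid or a primary amine on a longer chain at this position would shift the number, and what the ethenyl link and the two chlorines each contribute.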